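The source may report more compounds than this note shows. Statements on the series, on what has been measured and on what is new or still open speak of the compounds shown alone.

Compound 1 `Oc1cccc(-c2cc(-c3ccccc3)cc(-c3cccs3)n2)c1` and compound 2 `Oc1cccc(-c2cc(-c3ccccc3)cc(-c3ccsc3)n2)c1` share a core in which only the thiophene differs. In a functional assay on HL-60 cells (Homo sapiens) for cytotoxicity, read by ELISA, with a stated time of 2 days (on this read-out higher numbers stand for weaker inhibition and lower numbers for stronger inhibition), compound 1 gives 14100 nM and compound 2 gives 10300 nM. The change thiophen-3-yl in place of thiophen-2-yl on an aromatic carbon therefore made a 1.4-fold lower number from compound 1 to compound 2 (0.14 log units; within the scatter). Compound 3 `Oc1ccc(-c2cc(-c3ccccc3)cc(-c3cccs3)n2)cc1` carries the other core: 4-hydroxyphenyl in place of 3-hydroxyphenyl on an aromatic carbon produced an 8.3-fold lower number from compound 1 to compound 3 (0.92 log units; beyond the scatter), and compound 3 gives 1700 nM in this assay.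

Compound 4 `Oc1ccc(-c2cc(-c3ccccc3)cc(-c3ccsc3)n2)cc1` is separated from compound 3 by thiophen-3-yl in place of thiophen-2-yl on an aromatic carbon. This is the same kind of change as that from compound 1 to compound 2, but the place differs: here the aromatic carbon is meta to a 4-hydroxyphenyl group rather than meta to a 3-hydroxyphenyl group. Because a 1.4-fold lower number from compound 1 to compound 2 (0.14 log units; within the scatter) stayed within the scatter, the step for compound 4 is expected to be a 1.3-fold lower number from compound 3 to compound 4 (0.12 log units; within the scatter), also within the scatter. Compound 4 is thus estimated at 1300 nM, between 500 nM and 3500 nM.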

Compound 4, half-maximal inhibitory concentration: 3600 nM
Beside the measured number, compound 4's estimate is 2.8-fold (0.44 log units) below it; the whole stated range lies below it.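

In this assay the swap to thiophen-3-yl gave a 2.1-fold higher number from compound 3 to compound 4 (0.33 log units; beyond the scatter), so this change did not carry over unaltered from one core to the other: the same change on two cores in this assay, a 1.4-fold lower number (0.14 log units; within the scatter) from compound 1 to compound 2 and a 2.1-fold higher number (0.33 log units; beyond the scatter) from compound 3 to compound 4, 2.9-fold (0.46 log units) apart, beyond the scatter of two such steps. The move to 4-hydroxyphenyl gave a 2.9-fold lower number from compound 2 to compound 4 (0.46 log units; beyond the scatter), a lower number with either thiophene but a step of a different size: the same change on two cores in this assay, an 8.3-fold lower number (0.92 log units; beyond the scatter) from compound 1 to compound 3 and a 2.9-fold lower number (0.46 log units; beyond the scatter) from compound 2 to compound 4, 2.9-fold (0.46 log units) apart, beyond the scatter of two such steps. Neither change therefore transfers as a fixed amount between these cores, although the four compounds do not show why the steps differ or whether the same holds for other compounds in the series.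

The compounds shown leave open how a methoxy group or an amine in place of the hydroxyl group would behave. They also leave open what a longer chain on the phenyl group would do.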